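Replacing Methoxy with tert-Butyl on a Shared Core

The compounds below may be only part of what the source reports. "The series", "measured", "known", "first", "only" and "open" are said of these compounds alone.

Compound 3 `COc1ccc2oc(N3CCN(C)CC3)nc2c1` stands lowest of the three measured compounds in a functional assay on ileum (strain Hartley) for agonist activity at 5-hydroxytryptamine receptor 3A (Cavia porcellus); on this read-out higher numbers stand for higher potency (the scale is a negative logarithm) and lower numbers for lower potency: compound 3 gives 4.78. Compound 1 `CN1CCN(c2nc3cc([N+](=O)[O-])ccc3o2)CC1`, which carries a nitro group on the same core, gives 6.1 in this assay, and compound 2 `Cc1cc(Cl)c2oc(N3CCN(C)CC3)nc2c1`, which carries chloro and methyl, gives 6.22. Both of those numbers lie beyond the scatter above compound 3, so compound 3 is the weakest measured member of the set.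

Compound 4 `CN1CCN(c2nc3cc(C(C)(C)C)ccc3o2)CC1` differs from compound 3 by tert-butyl in place of methoxy on an aromatic carbon.

Within the data shown here, only one measured step bears on this change at the same place: a number 1.32 log units lower from compound 1 to compound 3 (beyond the scatter), a large step. It shows that the group at this place can move the number well beyond the scatter, and that methoxy gives the weakest result seen. Among the measured compounds shown here, no measured pair shows tert-butyl against any other group, so the direction for compound 4 rests on the observation that every other group tried at this place gave a higher number than methoxy. Compound 4 is therefore expected to move upward from compound 3, by a number 0.72 log units higher from compound 3 to compound 4 (beyond the scatter), though with wide uncertainty. The estimate for compound 4 is 5.5, within a range from 4.6 to 6.4.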

Compound 4, negative logarithm of the half-maximal effective concentration: < 4
Compound 4: a limit, no number; the forecaster's own chance of this, stated with the estimate: 10%; middle value at least 1.50 log units from the limit.
By their numbers in this assay, from the lowest: compound 3; then compounds 1 and 2 (each within the scatter of the next). At a limit, below all of these: compound 4.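

In this assay compound 4 gives a limit and not a number: the limit of < 4 in this assay, at which 1 of the 4 values shown sits.

Even so, tert-butyl in place of methoxy on an aromatic carbon gives a number at least 0.78 log units lower from compound 3 to compound 4 (beyond the scatter), so methoxy no longer marks the bottom of the range at this place. Tert-butyl in place of nitro gives a number at least 2.10 log units lower from compound 1 to compound 4 (beyond the scatter), a wider span at this single place than a number 1.32 log units lower from compound 1 to compound 3 (beyond the scatter) had shown, and the groups tried here now fall on both sides of methoxy, with nitro giving the higher number and tert-butyl the lower.

The compounds shown leave open how far compound 4 lies under its limit, and whether the drop follows the count of heavy atoms, 4 in tert-butyl against 2 in methoxy, or the hydrogen-bond acceptor that methoxy has and tert-butyl lacks. An amine, a fluorine atom or a short chain such as ethyl at this place would help to tell these two readings apart, as none of them appears among the compounds shown.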